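Moving the Methoxy Group in a Sulfonamide Series

The source may report more compounds than this note shows. Statements on the series, on what has been measured and on what is new or still open speak of the compounds shown alone.

Three measured compounds share one core and differ only in the aryl group on a saturated chain carbon bound to an amine nitrogen. Compound 1 `O=S(=O)(NCCCNCc1ccc(Cl)c(Cl)c1)c1cc(C(F)(F)F)cc(C(F)(F)F)c1` gives 1500 nM in a functional assay on A2780 cells (Homo sapiens) for inhibition, read by MTT assay, with a stated time of 72 h; on this read-out lower numbers stand for stronger inhibition of growth and higher numbers for weaker inhibition of growth. Compound 2 `O=S(=O)(NCCCNCc1ccc(Br)cc1)c1cc(C(F)(F)F)cc(C(F)(F)F)c1` gives 2600 nM in this assay, and compound 3 `COc1ccc(CNCCCNS(=O)(=O)c2cc(C(F)(F)F)cc(C(F)(F)F)c2)cc1` gives 1700 nM. Compound 3 thus stands second highest of the three numbers, though every step among them is small: a 1.7-fold higher number from compound 1 to compound 2 (0.24 log units; within the scatter), a 1.1-fold higher number from compound 1 to compound 3 (0.05 log units; within the scatter) and a 1.5-fold lower number from compound 2 to compound 3 (0.18 log units; within the scatter) all lie within the scatter, so the three aryl groups cannot be told apart on these data.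

Compound 4 `COc1ccccc1CNCCCNS(=O)(=O)c1cc(C(F)(F)F)cc(C(F)(F)F)c1` is the next member. Its change from compound 3 is 2-methoxyphenyl in place of 4-methoxyphenyl on a saturated chain carbon bound to an amine nitrogen. For the measured compounds named here, the three measured steps bear on it only loosely: they exchanged one aryl group for another and left the number essentially unchanged, and none of them moved a substituent around the ring, so there is no direct precedent for this shift. Given that exchanging whole aryl groups produced nothing beyond the scatter, the expected step of a 1.1-fold higher number from compound 3 to compound 4 (0.02 log units; within the scatter) is likewise none beyond the scatter. Compound 4 is therefore estimated at 1800 nM in this assay, with a range from 900 nM to 3600 nM.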

Compound 4, concentration for 50% growth inhibition: 1500 nM
Compound 4: the middle estimate sits 1.2-fold (0.08 log units) above what was measured; measured number inside the range.
By their numbers in this assay, from the lowest: compounds 1, 4, 3 and 2 (each within the scatter of the next).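

Moving the methoxy group from 4-methoxyphenyl to 2-methoxyphenyl is the only step here that rearranges the same atoms rather than exchanging one aryl group for another, and in this assay it gives a 1.1-fold lower number from compound 3 to compound 4 (0.05 log units; within the scatter). The new aryl group also cannot be separated from the other two, with a 1.7-fold lower number from compound 2 to compound 4 (0.24 log units; within the scatter) and no change at the digits printed from compound 1 to compound 4 (within the scatter), so on a saturated chain carbon bound to an amine nitrogen neither the change of substituent nor this shift of the methoxy group produces a step beyond the scatter. No supporting measurement bears on why these four compounds read so closely together.

On these data alone, all four aryl groups carry only halogen or methoxy substituents, so it remains open whether an amine or a carboxylic acid on the phenyl ring would give a step beyond the scatter at this place. It is equally open how the number would respond to a longer chain in the linker or to replacing a trifluoromethyl group on the shared core, since every compound shown keeps both of these parts unchanged.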